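Working notes: from compound 3 to compound 4

The source may hold more compounds than are shown below. What is called first, only, known or untested is meant among the compounds shown, and "the series" means these compounds.

In a functional assay on Gurav cells (Homo sapiens) for inhibition, read by sulforhodamine B assay (a lower number here means a stronger inhibitor of growth, a higher number a weaker inhibitor of growth), compound 1 `c1ccc(-c2ccc(-c3ccc(-c4nc5ccccc5[nH]4)cc3)cc2)cc1` gives 100000 nM, compound 2 `Fc1ccc(-c2ccc(-c3ccc(-c4nc5ccccc5[nH]4)cc3)cc2)cc1` gives 100000 nM and compound 3 `COc1ccc(-c2ccc(-c3ccc(-c4nc5ccccc5[nH]4)cc3)cc2)cc1` gives 38100 nM. Compound 3 therefore holds the lowest number of the three, and its steps to both others lie beyond the scatter.

The next structure is compound 4 `COc1ccc(-c2ccc(-c3ccc(-c4nc5ccccc5[nH]4)cc3)cc2)cc1OC`, which differs from compound 3 as follows: methoxy in place of hydrogen on an aromatic carbon. This is methoxy in place of hydrogen on an aromatic carbon, ortho to the methoxy group already present, turning 4-methoxyphenyl into 3,4-dimethoxyphenyl.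

For the measured compounds named here, the closest precedent is the earlier methoxy addition, a 2.6-fold lower number from compound 1 to compound 3 (0.42 log units; beyond the scatter). The exchange of fluoro for methoxy reads the same way, a 2.6-fold lower number from compound 2 to compound 3 (0.42 log units; beyond the scatter), while fluoro in place of hydrogen gave no change at the digits printed from compound 1 to compound 2 (within the scatter). Going by the values given here, only one measured step adds a methoxy to a hydrogen position, and none tests this new place or a pair of methoxy groups. A small further fall in this assay is the likeliest outcome, no larger than the modest earlier step, and no change is also plausible.

The expected step is a 1.3-fold lower number from compound 3 to compound 4 (0.10 log units; within the scatter), which may not clear the scatter.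

Compound 4 is estimated at 30000 nM, with an expected range of 11000 nM to 100000 nM.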

Compound 4, concentration for 50% growth inhibition: 9230 nM
Estimate against measurement, compound 4: 3.3-fold (0.51 log units) above; measured number outside the range, below it.
By their numbers in this assay, from the lowest: compound 4; then compound 3; then compounds 1 and 2 (each within the scatter of the next).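

In this assay, methoxy in place of hydrogen ortho to a methoxy group gives a 4.1-fold lower number from compound 3 to compound 4 (0.62 log units; beyond the scatter), so this ring position responds to substitution and a second methoxy group can still lower the number beyond the scatter. Taken as a whole, 3,4-dimethoxyphenyl gives an 11-fold lower number from compound 1 to compound 4 (1.03 log units; beyond the scatter) and, from the fluoro compound, an 11-fold lower number from compound 2 to compound 4 (1.03 log units; beyond the scatter); these are the first steps in the series printed as large, whereas each step to compound 3 is printed as modest. No supporting data are available to explain the fall in the number, so the result stands as an observation on these four compounds only.

From the compounds shown here alone, whether the new methoxy group would lower the number on its own, without the methoxy group it sits ortho to, stays open, as does whether the two groups are both needed for the large steps. Going by these compounds, it is also open whether a hydroxy group, an amine or a longer chain such as ethoxy at this position would give a similar fall, or whether a third methoxy group on the same ring would lower the number further.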